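Aryl exchange on the shared core: expectation for compound 3

A few compounds are considered here, and "the series" means these few. Any claim that something is new, unique, unknown or untested is made for them only; others in the source may bear on it.

In an assay on IMR-32 cells for inhibition of Voltage-dependent N-type calcium channel subunit alpha-1B (Homo sapiens), with a stated time of 5 min (a higher number here means a weaker inhibitor, a lower number a stronger inhibitor), compound 2 `COc1c(Cl)cc(C2C(C(=O)O)=CNC(C(OC)OC)=C2C(=O)OC/C=C/c2ccccc2)cc1Cl` gives 1200 nM. Among the measured compounds shown here, the only other measured compound, compound 1 `COC(OC)C1=C(C(=O)OC/C=C/c2ccccc2)C(c2cccc(Cl)c2)C(C(=O)O)=CN1`, gives 1100 nM in this assay, and the two numbers lie within the scatter of each other, so neither can be set above the other. Compound 3 `COC(OC)C1=C(C(=O)OC/C=C/c2ccccc2)C(c2cccc(C(F)(F)F)c2)C(C(=O)O)=CN1` differs from compound 2 at a single place: 3-(trifluoromethyl)phenyl in place of 3,5-dichloro-4-methoxyphenyl on a saturated ring carbon. For the measured compounds named here, the one measured step that bears on this is the earlier exchange of the aryl group at the same saturated ring carbon, a 1.1-fold higher number from compound 1 to compound 2 (0.04 log units; within the scatter), which produced no change beyond the scatter. On that basis no step beyond the scatter is expected in this assay in either direction. For compound 3 the expected value is 1100 nM, with a range from 450 nM to 2700 nM. This estimate means a step of a 1.1-fold lower number from compound 2 to compound 3 (0.04 log units; within the scatter) that is expected to remain within the scatter.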

Compound 3, half-maximal inhibitory concentration: 1100 nM
Compound 3: the middle estimate sits on the measured number at the digits printed; the range from low to high includes it.
By their numbers in this assay, from the lowest: compounds 1, 3 and 2 (each within the scatter of the next).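

In this assay the aryl group on the saturated ring carbon has now been exchanged a second time, and 3-(trifluoromethyl)phenyl in place of 3,5-dichloro-4-methoxyphenyl gives a 1.1-fold lower number from compound 2 to compound 3 (0.04 log units; within the scatter), so three different aryl groups at this position cannot be told apart. The new comparison with compound 1 narrows the change to one substituent: trifluoromethyl in place of chloro on an aromatic carbon gives no change at the digits printed from compound 1 to compound 3 (within the scatter), which shows that this exchange also leaves the number within the scatter. Nothing available explains why these exchanges leave the number in place. The compounds shown leave open whether an aryl group carrying an amine or a carboxylic acid would keep the number within the scatter at this carbon. They also leave open what a cyclohexyl group in place of the aryl group would do there.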